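The source may hold more compounds than are shown below. What is called first, only, known or untested is meant among the compounds shown, and "the series" means these compounds.

In a functional assay on HepG2 cells (Homo sapiens) for inhibition, read by MTT assay, with a stated time of 72 h (on this read-out lower numbers stand for stronger inhibition and higher numbers for weaker inhibition), three compounds sharing one core have been measured. Compound 1 `O=C1/C(=C\c2ccccc2)c2c(ncn2COCc2ccccc2)CCN1Cc1ccc(F)cc1` gives 39400 nM, compound 2 `Cc1cc(C)cc(CN2CCc3ncn(COCc4ccccc4)c3/C(=C/c3ccccc3)C2=O)c1` gives 40900 nM and compound 3 `O=C1/C(=C\c2ccccc2)c2c(ncn2COCc2ccccc2)CCN1Cc1ccc(-c2ccccc2)cc1` gives 72500 nM. Compound 3 therefore stands level with the other two, its value lying within the usual scatter of both.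

Compound 4 `O=C1/C(=C\c2ccccc2)c2c(ncn2COCc2ccccc2)CCN1Cc1ccc(Cl)cc1` differs from compound 3 in one group: chloro in place of phenyl on an aromatic carbon. Here 4-phenylphenyl gives way to 4-chlorophenyl.

The closest measured change is a 1.8-fold higher number from compound 1 to compound 3 (0.26 log units; within the scatter), which swaps the same kind of groups, read in the opposite direction, with fluoro rather than chloro. Two further changes to this group bear on the question: a 1.8-fold higher number from compound 2 to compound 3 (0.25 log units; within the scatter) and a 1.0-fold higher number from compound 1 to compound 2 (0.02 log units; within the scatter). For the measured compounds named here, none of these three steps leaves the scatter, although they rest on only three compounds. No step beyond the scatter is therefore expected in this assay, and no firm direction can be called. The estimated step is a 1.6-fold lower number from compound 3 to compound 4 (0.21 log units; within the scatter). For compound 4, the expected value is 45000 nM, with an estimated range of 25000 nM to 80000 nM.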

Compound 4, half-maximal inhibitory concentration: 47900 nM
For compound 4 the middle estimate is 1.1-fold (0.03 log units) below the measured one; low and high end bracket the measured number.
By their numbers in this assay, from the lowest: compounds 1, 2, 4 and 3 (each within the scatter of the next).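

In this assay, a 1.5-fold lower number from compound 3 to compound 4 (0.18 log units; within the scatter), so a single chlorine atom can take the place of a whole aromatic ring on this aromatic carbon without a step beyond the scatter. Chloro in place of fluoro at the same carbon gives a 1.2-fold higher number from compound 1 to compound 4 (0.08 log units; within the scatter), and 4-chlorophenyl in place of 3,5-dimethylphenyl gives a 1.2-fold higher number from compound 2 to compound 4 (0.07 log units; within the scatter), both also within the scatter, so the four groups shown at this end of the molecule all stand level. Nothing available explains why these values stay so close.

Still open, from the compounds shown here alone, is whether any group here can move the number beyond the scatter, for instance an amine or a carboxylic acid on this aromatic ring. Going by these compounds, the rest of the shared core is the same in all four compounds, so the contribution of its other parts also remains open.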